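Moving the pyridine nitrogen on a fatty-acid amide hydrolase inhibitor

The source may report more compounds than this note shows. Statements on the series, on what has been measured and on what is new or still open speak of the compounds shown alone.

Compound 1: `O=C(CCc1ccc(-c2ccccc2)cc1)c1ncc(-c2ccncc2)o1`, 2.3 nM
Compound 2: `CCOC(=O)c1cccc(-c2cnc(C(=O)CCc3ccc(-c4ccccc4)cc3)o2)n1`, 3 nM

Of the compounds shown here, two share the same core and have been measured in an assay for inhibition of Fatty-acid amide hydrolase 1 (Rattus norvegicus); on this read-out lower numbers stand for stronger inhibition and higher numbers for weaker inhibition. Compound 1 gives 2.3 nM and compound 2 gives 3 nM; the two values lie within the scatter of each other, so nothing separates them. Compound 1 holds the lowest number of the two.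

Compound 3, `O=C(CCc1ccc(-c2ccccc2)cc1)c1ncc(-c2cccnc2)o1`, has not yet been measured. It differs from compound 1 in one place: pyridin-3-yl in place of pyridin-4-yl on an aromatic carbon. The same atoms are present, only joined differently, so the ring nitrogen sits at another position of the same six-membered ring.

Going by the values given here, no step between measured compounds is available to guide this change. Given how close compound 1 and compound 2 are, the step from compound 1 to compound 3 is expected to be small, a 1.7-fold higher number from compound 1 to compound 3 (0.24 log units; within the scatter), likely no further than the scatter. Compound 3 is therefore estimated at 4 nM, with a range from 1.5 nM to 12 nM.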

Compound 3, inhibition constant: 1.1 nM
The estimate for compound 3 lay 3.6-fold (0.56 log units) above the measured number; the whole stated range lies above it.
By their numbers in this assay, from the lowest: compound 3; then compounds 1 and 2 (each within the scatter of the next).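

In this assay, the position on the aromatic carbon next to the ring oxygen responds to where the pyridine nitrogen sits: pyridin-3-yl in place of pyridin-4-yl gives a 2.1-fold lower number from compound 1 to compound 3 (0.32 log units; beyond the scatter). The two groups have the same atoms and the same counts of hydrogen-bond donors and acceptors, so the step comes with a move of the ring nitrogen alone, a modest but readable change. No measurement at hand tells why this move changes the number.

Open, as far as these compounds go, is whether pyridin-2-yl, the remaining placement of the nitrogen, would lower the number further or raise it. Also open, from the compounds shown here alone, is whether any ring nitrogen is needed here at all, which a phenyl ring at the same position would test.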